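The source may hold more compounds than are shown below. What is called first, only, known or untested is meant among the compounds shown, and "the series" means these compounds.

In an ADME assay on HepG2 cells (Homo sapiens) for cytotoxicity, read by MTT assay, with a stated time of 48 h, tested at 1 uM (a higher number here means a stronger effect of the compound at the concentration tested, a lower number a weaker effect), compound 1 `O=c1cc(-c2ccc(Cl)cc2)oc2cc(OCCCCCCCCN3CCCC3)ccc12` gives 6.39%, and compound 2 `COc1ccccc1-c1cc(=O)c2ccc(OCCCCCCCCN3CCCC3)cc2o1` gives 5.9%. The single step between them, a number 0.5 percentage points lower from compound 1 to compound 2 (within the scatter), is one the scatter of this assay swallows, so compound 2 stands on the numbers shown side by side with compound 1: two weak effects that cannot be told apart.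

Compound 3 `COc1cc(-c2cc(=O)c3ccc(OCCCCCCCCN4CCCC4)cc3o2)cc(OC)c1OC` is the next compound to be tested. It differs from compound 2 only in the group attached to the shared core: 3,4,5-trimethoxyphenyl in place of 2-methoxyphenyl on an aromatic carbon.

Within the data shown here, only one measured step bears on this change, namely the exchange of one phenyl substituent for another between compound 1 and compound 2, and that step stayed within the scatter. Nothing in the measured pair shows that the aryl group at this position moves the read-out in this assay. The step from compound 2 to compound 3 is therefore expected to be small, a number 1.1 percentage points higher from compound 2 to compound 3 (within the scatter), with no direction beyond the scatter. For compound 3 the expected value in this assay is estimated at 7%, within a range of 0% to 18%.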

Compound 3, a percentage reported as inhibition, at one concentration (the size of the read-out at that concentration, not a potency): 16.3%
Compound 3: the middle estimate sits 9.3 percentage points below what was measured; low and high end bracket the measured number.
By their numbers in this assay, from the lowest: compounds 2, 1 and 3 (each within the scatter of the next, the first and the last beyond it).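

In this assay, the aryl group on this aromatic carbon, next to the ring oxygen, proves able to move the read-out: a number 10.4 percentage points higher from compound 2 to compound 3 (beyond the scatter) when 3,4,5-trimethoxyphenyl replaces 2-methoxyphenyl, the only step among these compounds beyond the scatter. The margin is narrow, since the same group entering in place of 4-chlorophenyl gives a number 9.9 percentage points higher from compound 1 to compound 3 (within the scatter) and so separates compound 3 clearly from compound 2 but not from compound 1. No independent evidence bears on why the change from compound 2 to compound 3 has this outcome.

The compounds shown leave open whether the larger read-out of compound 3 needs all three methoxy groups, or whether a single methoxy group in the 4-position or a 3,4-dimethoxyphenyl group would give the same, and whether a 3,4,5-trimethoxyphenyl group that lifts the read-out here would do so in a wider series. They also leave open how this aryl change would behave with a piperidine or morpholine in place of the pyrrolidine, or with a shorter chain joining that amine to the shared core.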